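Swapping a Chlorophenyl for a Hydroxyphenyl on the Amide

The compounds below may be only part of what the source reports. "The series", "measured", "known", "first", "only" and "open" are said of these compounds alone.

Measured in a functional assay on SMMC-7721 cells (Homo sapiens) for cytotoxicity, read by MTT assay, with a stated time of 72 h; on this read-out higher numbers stand for weaker inhibition and lower numbers for stronger inhibition:
Compound 1, `O=C(CSC(=S)N[C@H]1CCOC1=O)Nc1ccccc1F`: > 128000 nM
Compound 2, `O=C(CSC(=S)N[C@H]1CCOC1=O)Nc1ccccc1Cl`: 49900 nM

Two compounds share one core and differ only in the group on the amide-type nitrogen. For compound 1 the value in this assay is a limit of the assay, not a number. Among the measured compounds shown here, compound 2 therefore stands alone as the single measured number, and the step of an at least 2.5-fold lower number from compound 1 to compound 2 (0.40 log units; beyond the scatter) is the only measured step, resting on (the limit of > 128000 nM in this assay, at which 1 of the 2 values shown sits).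

Compound 3, `O=C(CSC(=S)N[C@H]1CCOC1=O)Nc1ccc(O)cc1`, has not been measured. It differs from compound 2 by 4-hydroxyphenyl in place of 2-chlorophenyl on an amide-type nitrogen. For the measured compounds named here, the one measured step concerns a change between two halogens, while this change trades a chlorine for a hydroxyl and moves the group to another position on the ring, so it bears on the new step only loosely: it shows that small changes on this ring can move the number by a modest amount or more. Going by the values given here, since the only measured compound with a number is compound 2, the estimate for compound 3 is expected to move upward, toward weaker inhibition, and is given as 90000 nM, between 35000 nM and 250000 nM, which means an expected step of a 1.8-fold higher number from compound 2 to compound 3 (0.26 log units; within the scatter).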

Compound 3, half-maximal inhibitory concentration: > 128000 nM
Compound 3 gave a limit, no number; the forecaster's own chance of this, stated with the estimate: 40%; middle value at least 1.4-fold (0.15 log units) away from the limit.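

In this assay compound 3 gives > 128000 nM, which is a limit of the assay and not a number. Among the compounds shown here, putting 4-hydroxyphenyl in place of 2-chlorophenyl on an amide-type nitrogen gives an at least 2.5-fold higher number from compound 2 to compound 3 (0.40 log units; beyond the scatter), so a second change at this position now leads away from the one compound with a measured number, and 2-chlorophenyl is the only group of the three that gives a readable value. The step between compound 1 and compound 3 cannot be read, and how far inhibition falls from compound 2 to compound 3 has no upper end, because both compounds rest on the same limit: the limit of > 128000 nM in this assay, at which 2 of the 3 values shown sit.

This step changes both the atom on the ring and its place on the ring at once, and the compounds shown do not tell these two effects apart. Going by these compounds, it also remains open whether an amine or a carboxylic acid on this ring, or a longer chain on the amide-type nitrogen, would keep or improve on the value of compound 2, 49900 nM.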